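This account rests on a few compounds, and the source may have more. Where it says the series, first, only, none or still open, it means among the compounds named here.

Measured in a functional assay on SW480 cells (Homo sapiens) for antiproliferative activity, read by MTT assay, with a stated time of 48 h; on this read-out higher numbers stand for weaker inhibition and lower numbers for stronger inhibition:
- compound 1 `CCN(CC)C/C1=C/C[C@](C)(CCC=C(C)C)/C=C/[C@@H](OC(=O)C=C(C)C)[C@](C)(O)/C=C/C1=O`: 270 nM
- compound 2 `CC(C)=CCC[C@]1(C)/C=C/[C@@H](OC(=O)C=C(C)C)[C@](C)(O)/C=C/C(=O)/C(CN(C(C)C)C(C)C)=C\C1`: 750 nM
- compound 3 `CC(C)=CCC[C@]1(C)/C=C/[C@@H](OC(=O)C=C(C)C)[C@](C)(O)/C=C/C(=O)/C(CN2CCCC2)=C\C1`: 310 nM

In this series, compound 3 at 310 nM cannot be told apart from compound 1, as the step of a 1.1-fold higher number from compound 1 to compound 3 (0.06 log units; within the scatter) shows. Compound 2 stands clear of both, and the step of a 2.4-fold lower number from compound 2 to compound 3 (0.38 log units; beyond the scatter) marks that gap.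

The next compound to consider is compound 4 `CC(C)=CCC[C@]1(C)/C=C/[C@@H](OC(=O)C=C(C)C)[C@](C)(O)/C=C/C(=O)/C(COC(=O)c2ccc([N+](=O)[O-])cc2)=C\C1`, which differs from compound 3 as follows: ((4-nitrophenyl)carbonyl)oxy in place of pyrrolidin-1-yl on a saturated chain carbon bound to a double-bonded ring carbon. In short, ((4-nitrophenyl)carbonyl)oxy stands in place of pyrrolidin-1-yl on a saturated chain carbon bound to a double-bonded ring carbon.

All three measured steps bear on this place, but each only exchanges one amino group for another. The largest, a 2.8-fold higher number from compound 1 to compound 2 (0.44 log units; beyond the scatter), is modest. For the measured compounds named here, no measured compound carries ((4-nitrophenyl)carbonyl)oxy, so the data offer only a weak guide to this larger change. Going by the values given here, the one step beyond the scatter that leaves compound 1 went upward, a 2.8-fold higher number from compound 1 to compound 2 (0.44 log units; beyond the scatter), so a modest rise in this assay is the cautious expectation, with wide uncertainty. The expected change is a 1.9-fold higher number from compound 3 to compound 4 (0.29 log units; within the scatter). For compound 4 the estimated value is 600 nM, with an expected range from 150 nM to 2500 nM.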

Compound 4, half-maximal inhibitory concentration: 570 nM
Beside the measured number, compound 4's estimate is 1.1-fold (0.02 log units) above it; the range from low to high includes it.
By their numbers in this assay, from the lowest: compounds 1, 3, 4 and 2 (each within the scatter of the next, the first and the last beyond it).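

Until now this place, on a saturated chain carbon bound to a double-bonded ring carbon, had carried only amino groups. Compound 4 shows that in this assay an amino group there is not required for a value in the same range, since its ((4-nitrophenyl)carbonyl)oxy group cannot be told apart from pyrrolidin-1-yl (a 1.8-fold higher number from compound 3 to compound 4 (0.26 log units; within the scatter)) or from diisopropylamino (a 1.3-fold lower number from compound 2 to compound 4 (0.12 log units; within the scatter)). Only the comparison with diethylamino separates the new group from the amines (a 2.1-fold higher number from compound 1 to compound 4 (0.32 log units; beyond the scatter)), and that step is modest, so the amines as a set do not stand clear of this much larger group, and nothing available explains why activity holds across this change.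

The compounds shown leave open whether the nitro group contributes anything, as they include no unsubstituted benzoyloxy group, and no acetyloxy or free hydroxyl at this place that would show how much of the ((4-nitrophenyl)carbonyl)oxy group is needed. They also leave open how a carboxylic acid or a morpholin-4-yl group would behave here, since every group shown so far is either a tertiary amine or this single aromatic ester.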